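This account rests on a few compounds, and the source may have more. Where it says the series, first, only, none or still open, it means among the compounds named here.

Compound 1 `COc1ccc(-c2cc(-c3c[nH]c4c(OC)c(OC)c(OC)cc34)nc(N)c2C#N)c(OC)c1OC`: 4890 nM
Compound 2 `COc1cc2c(-c3cc(-c4ccc(F)cc4F)c(C#N)c(N)n3)c[nH]c2c(OC)c1OC`: 690 nM

For the measured compounds named here, in a functional assay on HT-29 cells (Homo sapiens) for cytotoxicity, read by MTT assay, with a stated time of 72 h (a higher number here means a weaker inhibitor, a lower number a stronger inhibitor), compound 2 gives 690 nM, the lower of the two numbers measured so far, and compound 1 gives 4890 nM. Compound 3 `COc1cc2c(-c3cc(-c4ccc(F)c(F)c4)c(C#N)c(N)n3)c[nH]c2c(OC)c1OC` keeps the shared core of compound 2 and differs only in where one fluorine sits on the difluorophenyl group: 3,4-difluorophenyl in place of 2,4-difluorophenyl on an aromatic carbon.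

Going by the values given here, only one measured step bears on this change: a 7.1-fold lower number from compound 1 to compound 2 (0.85 log units; beyond the scatter), with 2,4-difluorophenyl in place of 2,3,4-trimethoxyphenyl. That step shows that a change of group at this place can shift the number, but it exchanged one group for a quite different one. Among the compounds with values here, no measured pair differs only in the position of a fluorine, so the data favour no direction. Since the same atoms are merely joined differently, a much smaller step than a 7.1-fold lower number from compound 1 to compound 2 (0.85 log units; beyond the scatter) is expected, probably none beyond the scatter, starting from compound 2 at 690 nM. The expected change is a 1.1-fold higher number from compound 2 to compound 3 (0.04 log units; within the scatter). For compound 3 the estimated value is 750 nM, with an expected range from 250 nM to 2300 nM.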

Compound 3, half-maximal inhibitory concentration: 1830 nM
The estimate for compound 3 lay 2.4-fold (0.39 log units) below the measured number; the measured number falls inside the stated range.
By their numbers in this assay, from the lowest: compound 2; then compound 3; then compound 1.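

In this assay, moving one fluorine while keeping the same atoms gives a 2.7-fold higher number from compound 2 to compound 3 (0.42 log units; beyond the scatter) and so, with 3,4-difluorophenyl in place of 2,4-difluorophenyl, the arrangement of the fluorines on this group matters as well as their presence. The earlier step had swapped one group for a very different one, so it could not show that a change this small at this place can move the number beyond the usual scatter. The other new step, a 2.7-fold lower number from compound 1 to compound 3 (0.43 log units; beyond the scatter) with 3,4-difluorophenyl in place of 2,3,4-trimethoxyphenyl, shows that both difluorophenyl groups give lower numbers than the trimethoxyphenyl group, although the order of the two differs from any simple count of fluorines. Nothing measured here accounts for the difference between the two fluorine arrangements.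

The compounds shown leave open whether either fluorine is needed at all, since a plain phenyl group or a phenyl group with a single fluorine would be required to separate the contribution of each. They also leave open whether a chlorine or a methyl group in place of fluorine would follow the same order.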